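Series notes: removing the aryl chloro from compound 1

This account rests on a few compounds, and the source may have more. Where it says the series, first, only, none or still open, it means among the compounds named here.

Measured compounds:
Compound 1 `Cc1nc(Nc2ccc(Cl)cc2)sc1C(=O)/C=C/c1ccccc1`. In a functional assay on Bel-7402 cells (Homo sapiens) for cytotoxicity, read by MTT assay (on this read-out lower numbers stand for stronger inhibition and higher numbers for weaker inhibition), compound 1 gives > 25000 nM, which is a limit of the assay.
Compound 2 `Cc1cccc(Nc2nc(C)c(C(=O)/C=C/c3ccccc3Cl)s2)c1`. In this assay compound 2 gives > 25000 nM, again a limit.
Compound 3 `Cc1nc(Nc2ccc(Cl)cc2)sc1C(=O)/C=C/c1ccc(Cl)cc1`. In this assay compound 3 gives > 25000 nM, also a limit.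

Compound 1 therefore stands at the limit, not on a number, and so do the other two measured compounds (the limit of > 25000 nM in this assay, at which 3 of the 3 values shown sit). For the measured compounds named here, the one single-point step among them, a step that the two limits leave unreadable from compound 1 to compound 3, is unreadable for the same reason. Compound 4 `Cc1nc(Nc2ccccc2)sc1C(=O)/C=C/c1ccccc1` differs from compound 1 by hydrogen in place of chloro on an aromatic carbon. Going by the values given here, no measured step bears readably on this change, so no direction beyond the scatter can be expected. Compound 4 is estimated at 30000 nM, within 8000 nM to 120000 nM. The expected step that the limit leaves unreadable from compound 1 to compound 4 is put at none, most likely ending at the limit again.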

Compound 4, half-maximal inhibitory concentration: > 25000 nM
Compound 4: a limit, no number; the forecaster's own chance of this, stated with the estimate: 80%; the middle value is on the limit's open side.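

Compound 1 and compound 4 both sit at a limit, so no step can be read between them: the limit of > 25000 nM in this assay, at which 4 of the 4 values shown sit. The compounds shown give no number, which leaves open whether hydrogen in place of chloro changes anything in this assay.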